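Shifting Methyl Groups on a Dimethylphenyl Sulfonamide

The source may hold more compounds than are shown below. What is called first, only, known or untested is meant among the compounds shown, and "the series" means these compounds.

Among the measured compounds shown here, in a functional assay on M21 cells (Homo sapiens) for antiproliferative activity, read by sulforhodamine B assay, with a stated time of 48 h (a lower number here means a stronger inhibitor, a higher number a weaker inhibitor), compound 1 `Cc1ccc(NS(=O)(=O)c2ccc(N3CCNC3=O)cc2)cc1C` gives 94 nM and compound 2 `Cc1cc(C)cc(NS(=O)(=O)c2ccc(N3CCNC3=O)cc2)c1` gives 63 nM, so compound 2 stands within the scatter of its only neighbour. Compound 3 `Cc1ccc(NS(=O)(=O)c2ccc(N3CCNC3=O)cc2)c(C)c1` has the same atoms joined differently: 2,4-dimethylphenyl in place of 3,5-dimethylphenyl on a sulfonamide nitrogen. For the measured compounds named here, the one measured step that bears on this is another swap between dimethylphenyl groups: a 1.5-fold lower number from compound 1 to compound 2 (0.17 log units; within the scatter). One small step is thin evidence, but no change beyond the scatter is expected in this assay. The expected step is a 1.6-fold higher number from compound 2 to compound 3 (0.20 log units; within the scatter). The estimate for compound 3 is 100 nM, with an expected range of 35 nM to 300 nM.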

Compound 3, half-maximal inhibitory concentration: 150 nM
The estimate for compound 3 lay 1.5-fold (0.18 log units) below the measured number; the measured number falls inside the stated range.
By their numbers in this assay, from the lowest: compounds 2, 1 and 3 (each within the scatter of the next, the first and the last beyond it).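

Rearranging the two methyl groups on this ring can change the result: in this assay, 2,4-dimethylphenyl in place of 3,5-dimethylphenyl gives a 2.4-fold higher number from compound 2 to compound 3 (0.38 log units; beyond the scatter), the only step here beyond the scatter, and a modest one. Replacing 3,4-dimethylphenyl with the same group gives a 1.6-fold higher number from compound 1 to compound 3 (0.20 log units; within the scatter), which stays within the scatter. Nothing available explains why these arrangements differ.

As far as these compounds go, whether a ring carrying methoxy groups or chlorine atoms would match compound 2 remains open. So does the outcome of a single methyl group on the ring.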